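Series notes: substituent swap on the fused aromatic ring

The source may report more compounds than this note shows. Statements on the series, on what has been measured and on what is new or still open speak of the compounds shown alone.

Measured so far:
Compound 1 `O=C(O)C1(Sc2ccnc3ccc(O)cc23)CCC1` in an assay on HEK293 cells for inhibition of solute carrier family 22 member 12 (Homo sapiens), read by scintillation counting, with a stated time of 12 min; on this read-out lower numbers stand for stronger inhibition and higher numbers for weaker inhibition: > 10000 nM
Compound 2 `CNC(=O)COc1ccc2nccc(SC3(C(=O)O)CCC3)c2c1` in this assay: > 10000 nM

Compound 1 gives only a limit in this assay, > 10000 nM. Compound 2 likewise gives only a limit, > 10000 nM. The step that the two limits leave unreadable from compound 1 to compound 2 is accordingly not readable; compound 2 stands at the same limit as compound 1, (the limit of > 10000 nM in this assay, at which 2 of the 2 values shown sit). Compound 3 `Cc1ccc2nccc(SC3(C(=O)O)CCC3)c2c1` differs from compound 2 by methyl in place of (methylcarbamoyl)methoxy on an aromatic carbon. Within the data shown here, no measured step bears on this change, since the single measured step is unreadable. With both recorded values being limits, compound 3 is expected to give in this assay again a limit, estimated at 15000 nM (range 4000 nM to 60000 nM), a step that the limit leaves unreadable from compound 2 to compound 3 expected to stay within scatter.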

Compound 3, half-maximal inhibitory concentration: 343 nM
Beside the measured number, compound 3's estimate is 44-fold (1.64 log units) above it; the whole stated range lies above it.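

Methyl on this aromatic carbon gives the first readable value in this assay, with an at least 29-fold lower number from compound 2 to compound 3 (1.46 log units; beyond the scatter) and with an at least 29-fold lower number from compound 1 to compound 3 (1.46 log units; beyond the scatter) in the same direction. Hydroxy and (methylcarbamoyl)methoxy, the two groups it replaces, are not separated, and that step cannot be read. Compound 1 and compound 2 give limits, not numbers: the limit of > 10000 nM in this assay, at which 2 of the 3 values shown sit.

On these data alone, the full size of the gain stays open, since both steps start from a limit. Also open, as far as these compounds go, is whether methyl is specific here, or whether an ethyl, a chlorine or an amine on this carbon gives a readable value as well.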